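The source may hold more compounds than are shown below. What is called first, only, known or untested is meant among the compounds shown, and "the series" means these compounds.

Measured compounds:
- compound 1, `N#Cc1ccc(Cc2cnc(CCc3ccc(-c4ccccc4C(=O)O)cc3)[nH]2)cc1`: 5890 nM
- compound 2, `CCCCc1cnc(C(CCC)Cc2ccc(-c3ccccc3C(=O)O)cc2)[nH]1`: 1180 nM
- compound 3, `CCCCc1cnc(C(C)Cc2ccc(-c3ccccc3C(=O)O)cc2)[nH]1`: 2760 nM

In an in vitro functional assay on cells for agonist activity at Bombesin receptor subtype-3 (Homo sapiens), read by luminescence and calcium flux (a higher number here means that more compound is needed for the effect, a lower number that less compound is needed), compound 1 stands highest of the three numbers, so it needs the most compound for the effect. Compound 3 is its nearest neighbour, and compound 2, with its lower number, lies furthest from it. Going by the values given here, the only change between measured compounds that differ in one place is a 2.3-fold higher number from compound 2 to compound 3 (0.37 log units; beyond the scatter), a change on a saturated chain carbon away from the site that matters here.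

The unmeasured compound 4, `O=C(O)c1ccccc1-c1ccc(CCc2ncc(CC3CCCC3)[nH]2)cc1`, differs from compound 1 in one place: cyclopentyl in place of 4-cyanophenyl on a saturated chain carbon bound to an aromatic carbon. A saturated ring takes the place of an aromatic ring with a nitrile. Among the compounds with values here, no measured step covers this kind of swap, so a direct guide is lacking. What the values do show is that compounds 2 and 3, which carry no 4-cyanophenyl, both give lower numbers than compound 1, though they also differ from it elsewhere. On that loose footing the step of a 2.4-fold lower number from compound 1 to compound 4 (0.37 log units; beyond the scatter) is expected to be a modest lowering, with wide uncertainty. Compound 4 is estimated to give 2500 nM in this assay, within a range from 700 nM to 9000 nM.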

Compound 4, half-maximal effective concentration: 133 nM
Compound 4: the middle estimate sits 19-fold (1.27 log units) above what was measured; the whole stated range lies above it.
By their numbers in this assay, from the lowest: compound 4; then compound 2; then compound 3; then compound 1.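

In this assay putting cyclopentyl in place of 4-cyanophenyl on a saturated chain carbon bound to an aromatic carbon gives a 44-fold lower number from compound 1 to compound 4 (1.65 log units; beyond the scatter) and marks this place as one where the choice of group counts heavily. Going by these compounds alone, the only earlier step is a 2.3-fold higher number from compound 2 to compound 3 (0.37 log units; beyond the scatter) at a different place and is modest by comparison, so the earlier compounds gave no sign that a single change could move the number this far. Compound 4 also shows that neither an aromatic ring nor a nitrile is required at this place for a low number, while nothing measured here explains why the number falls so far.

Whether the fall follows the loss of the nitrile, the loss of the aromatic ring, or the drop from 8 heavy atoms to 5 stays unsettled, as all three change together in this one step. Also open, going by these compounds, is how an unsubstituted phenyl, a cyclohexyl or a cyclopentyl ring carrying a hydroxyl group would read at this place, and whether cyclopentyl would lower the number on the core of compound 2 or compound 3 as well.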